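Fluoro for Methoxy in a Weak Inhibitor Pair

A few compounds are considered here, and "the series" means these few. Any claim that something is new, unique, unknown or untested is made for them only; others in the source may bear on it.

In a functional assay on U-373MG ATCC cells (Homo sapiens) for inhibition, read by colorimetric assay and MTT assay, with a stated time of 72 h (on this read-out lower numbers stand for stronger inhibition and higher numbers for weaker inhibition), compound 1 (`C=CCCCCOc1ccc(C)cc1-c1cnc(OCCC=C)n1C`) gives 33000 nM and compound 2 (`C=CCCCCOc1ccc(OC)cc1-c1cnc(OCCC=C)n1C`) gives 67000 nM as the higher number of the two. Compound 3 (`C=CCCCCOc1ccc(F)cc1-c1cnc(OCCC=C)n1C`) has fluoro in place of methoxy on an aromatic carbon, para to a (hex-5-en-1-yl)oxy group (fluoro in place of methoxy on an aromatic carbon). Within the data shown here, the one measured step bearing on this is a 2.0-fold higher number from compound 1 to compound 2 (0.31 log units; beyond the scatter) on methoxy replacing methyl, modest and beyond the scatter, so a similarly modest move toward a lower number is expected for compound 3. The estimate means a 1.8-fold lower number from compound 2 to compound 3 (0.25 log units; within the scatter) as the expected step. Compound 3 is estimated at 38000 nM with an expected range from 17000 nM to 80000 nM in this assay.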

Compound 3, half-maximal inhibitory concentration: 73000 nM
For compound 3 the middle estimate is 1.9-fold (0.28 log units) below the measured one, and the stated range covers the measured number.
By their numbers in this assay, from the lowest: compound 1; then compounds 2 and 3 (each within the scatter of the next).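

Fluoro in place of methoxy, para to a (hex-5-en-1-yl)oxy group, gives a 1.1-fold higher number from compound 2 to compound 3 (0.04 log units; within the scatter) in this assay on this read-out, so the two groups cannot be told apart here, although one heavy atom replaces two. Fluoro in place of methyl gives a 2.2-fold higher number from compound 1 to compound 3 (0.34 log units; beyond the scatter) at the same position, which leaves methyl as the only group of the three set apart from the others. Nothing measured here gives a reason for this grouping. From the compounds shown here alone, whether an amine, a carboxylic acid or a longer chain at this position would move the number away from this narrow band remains open, as does whether any change to the hex-5-en-1-yl chain would do so.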